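This account rests on a few compounds, and the source may have more. Where it says the series, first, only, none or still open, it means among the compounds named here.

Compound 1 `COc1cc2c(Nc3ccc(C#N)cc3)ncnc2cc1OCCCN1CCCCC1` carries an unsubstituted piperidine at the end of its chain. In a functional assay on DU-145 cells (Homo sapiens) for antiproliferative activity, read by MTT assay, with a stated time of 72 h (on this read-out lower numbers stand for stronger inhibition and higher numbers for weaker inhibition), compound 1 gives 24400 nM. Compound 2 `COc1cc2c(Nc3ccc(C#N)cc3)ncnc2cc1OCCCN1CCCCC1CCO` adds a 2-hydroxyethyl group to a saturated ring carbon of that piperidine. In this assay compound 2 reaches only the limit of the assay, > 100000 nM, so no number is known for it. The step of an at least 4.0-fold higher number from compound 1 to compound 2 (0.61 log units; beyond the scatter) can only be given as a lower bound because the limit of > 100000 nM in this assay, at which 1 of the 2 values shown sits, caps it. Compound 3 `CCOC(=O)C1CCN(CCCOc2cc3ncnc(Nc4ccc(C#N)cc4)c3cc2OC)CC1` differs from compound 2 by 4-(ethoxycarbonyl)piperidin-1-yl in place of 2-(2-hydroxyethyl)piperidin-1-yl on a saturated chain carbon, three bonds along the chain from an oxygen on an aromatic ring. Going by the values given here, the one measured step, from compound 1 to compound 2, bears on this only loosely: it shows that a substituent on the piperidine can push the value past the limit, but the new group is a different substituent on that ring. Compound 3 is therefore expected to land between the two measured values, with an at least 1.6-fold lower number from compound 2 to compound 3 (0.22 log units; that floor lies within the scatter) as a weakly favorable step. The estimate for compound 3 is 60000 nM, within 15000 nM to 150000 nM.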

Compound 3, half-maximal inhibitory concentration: 52300 nM
Compound 3: middle estimate off by 1.1-fold (0.06 log units), on the high side; the range from low to high includes it.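

With ethoxycarbonyl on a saturated ring carbon, the piperidine keeps a readable value in this assay, and the change gives a 2.1-fold higher number from compound 1 to compound 3 (0.33 log units; beyond the scatter), a modest loss. Both substituted piperidines shown, in compound 2 and compound 3, therefore read weaker than the unsubstituted ring of compound 1, with no compound here going against that. The comparison with the hydroxyethyl compound gives an at least 1.9-fold lower number from compound 2 to compound 3 (0.28 log units; that floor lies within the scatter), so it cannot show that 4-(ethoxycarbonyl)piperidin-1-yl truly improves on 2-(2-hydroxyethyl)piperidin-1-yl, and it remains a floor: the limit of > 100000 nM in this assay, at which 1 of the 3 values shown sits.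

Compound 2 and compound 3 differ both in the group and in where it sits on the ring, and these two changes cannot be separated here. Also open, on these data alone, is how a piperidine carrying a carboxylic acid in place of the ethyl ester would read.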